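The source may hold more compounds than are shown below. What is called first, only, known or untested is meant among the compounds shown, and "the series" means these compounds.

Working notes on the series

Compound 1 `O=C(/C=C/c1cccc(F)c1)Nc1ccc(CC2=CC(=O)OC2)cc1` carries the six-heavy-atom lactone ring on the benzylic carbon and a 3-fluorophenyl on the acrylamide. In a functional assay on A549 cells (Homo sapiens) for cytotoxicity, read by MTT assay, with a stated time of 48 h (a lower number here means a stronger inhibitor, a higher number a weaker inhibitor), compound 1 gives > 50000 nM, which is a limit of the assay and not a number; it sits at the limit of > 50000 nM in this assay, at which 1 of the 3 values shown sits.

Compound 2 `C=C1OC(=O)C=C1Cc1ccc(NC(=O)/C=C/c2cccc(F)c2)cc1` differs from compound 1 by a group of 7 heavy atoms (5 carbon, 2 oxygen; one five-membered non-aromatic ring with 1 hetero atom) in place of a group of 6 heavy atoms (4 carbon, 2 oxygen; one five-membered non-aromatic ring with 1 hetero atom), on a saturated chain carbon bound to an aromatic carbon. In this assay compound 2 gives 35200 nM. The step is an at least 1.4-fold lower number from compound 1 to compound 2 (0.15 log units; that floor lies within the scatter), so the change from the six-heavy-atom ring to the seven-heavy-atom ring cannot be told apart from no change on this evidence.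

Compound 3 `O=C(/C=C/c1ccc(F)cc1)Nc1ccc(CC2=CC(=O)OC2)cc1` differs from compound 1 by 4-fluorophenyl in place of 3-fluorophenyl on a double-bonded chain carbon bound to a double-bonded chain carbon. In this assay compound 3 gives 41800 nM, and the step is an at least 1.1-fold lower number from compound 1 to compound 3 (0.07 log units; that floor lies within the scatter). Compound 3 and compound 2 lie within the scatter of each other.

Compound 4 `C=C1OC(=O)C=C1Cc1ccc(NC(=O)/C=C/c2ccc(F)cc2)cc1` is not yet measured in this assay. It differs from compound 3 by a group of 7 heavy atoms (5 carbon, 2 oxygen; one five-membered non-aromatic ring with 1 hetero atom) in place of a group of 6 heavy atoms (4 carbon, 2 oxygen; one five-membered non-aromatic ring with 1 hetero atom), on a saturated chain carbon bound to an aromatic carbon; the place is worded identically to that of the change from compound 1 to compound 2, so this is the same change, made on the core of compound 3 rather than the core of compound 1. The two cores differ by 4-fluorophenyl in place of 3-fluorophenyl on a double-bonded chain carbon bound to a double-bonded chain carbon. The step expected from compound 3 to compound 4 is a 1.4-fold lower number from compound 3 to compound 4 (0.14 log units; within the scatter), resting on the earlier step of an at least 1.4-fold lower number from compound 1 to compound 2 (0.15 log units; that floor lies within the scatter), which was itself within the scatter. In this assay compound 4 is estimated at 30000 nM, with a range from 14000 nM to 60000 nM.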

Compound 4, half-maximal inhibitory concentration: 3460 nM
For compound 4 the middle estimate is 8.7-fold (0.94 log units) above the measured one; measured number outside the range, below it.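

In this assay the seven-heavy-atom ring in place of the six-heavy-atom ring, on the core of compound 3, gives a 12-fold lower number from compound 3 to compound 4 (1.08 log units; beyond the scatter), and 4-fluorophenyl in place of 3-fluorophenyl, on the core of compound 2, gives a 10-fold lower number from compound 2 to compound 4 (1.01 log units; beyond the scatter); both steps are large. This does not show whether the ring change keeps its size from one core to the other, and a step of similar size on the core of compound 1 is not excluded: the same change on two cores in this assay, an at least 1.4-fold lower number (0.15 log units; that floor lies within the scatter) from compound 1 to compound 2 and a 12-fold lower number (1.08 log units; beyond the scatter) from compound 3 to compound 4; the limit leaves it open whether they differ The fluorophenyl change stands the same way, so a dependence on the core is neither shown nor ruled out: the same change on two cores in this assay, an at least 1.1-fold lower number (0.07 log units; that floor lies within the scatter) from compound 1 to compound 3 and a 10-fold lower number (1.01 log units; beyond the scatter) from compound 2 to compound 4; the limit leaves it open whether they differ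

The compounds shown leave open whether the large steps to compound 4 hold when a chlorine atom or a methoxy group replaces the fluorine of the 4-fluorophenyl group. They also leave open whether the seven-heavy-atom ring gives a step of this size when a longer chain replaces the saturated chain carbon that carries it.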